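Trifluoromethyl for Chloro on the Anilino Ring

The source may report more compounds than this note shows. Statements on the series, on what has been measured and on what is new or still open speak of the compounds shown alone.

Going by the values given here, compound 2 `O=C(/C=C\Nc1ccc(Cl)cc1)c1cn(-c2ccccc2)nc1-c1ccc(Cl)cc1` is the one compound here with a number: in a functional assay on U-87MG ATCC cells (Homo sapiens) for antiproliferative activity, read by MTT assay, with a stated time of 48 h (on this read-out higher numbers stand for weaker inhibition and lower numbers for stronger inhibition), compound 2 gives 13100 nM. Compound 1 `O=C(/C=C\Nc1ccc(C(F)(F)F)cc1)c1cn(-c2ccccc2)nc1-c1ccccc1` gives > 50000 nM, which is a limit of this assay and not a number. That result stands at the limit of > 50000 nM in this assay, at which 1 of the 2 values shown sits. Compound 3 `O=C(/C=C\Nc1ccc(C(F)(F)F)cc1)c1cn(-c2ccccc2)nc1-c1ccc(Cl)cc1` differs from compound 2 by trifluoromethyl in place of chloro on an aromatic carbon, so that compound 3 shares the (4-(trifluoromethyl)phenyl)amino group of compound 1. Among the compounds with values here, no measured pair shows this change directly; a weakening beyond the scatter is expected, as a 2.3-fold higher number from compound 2 to compound 3 (0.36 log units; beyond the scatter). Compound 3 is therefore estimated at 30000 nM, with a range from 12000 nM to 80000 nM.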

Compound 3, half-maximal inhibitory concentration: > 50000 nM
Compound 3 gave a limit, no number; the forecaster's own chance of this, stated with the estimate: 35%; at least 1.6-fold (0.22 log units) between middle value and limit.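

Going from the (4-chlorophenyl)amino group to the (4-(trifluoromethyl)phenyl)amino group gives an at least 3.8-fold higher number from compound 2 to compound 3 (0.58 log units; beyond the scatter), the first readable step for this change on an aromatic carbon in this assay. Compound 3 keeps the second chloro of compound 2 yet reaches only a limit, not a number. The step between compound 1 and compound 3 cannot be read, and the limit now holds most of the series: the limit of > 50000 nM in this assay, at which 2 of the 3 values shown sit.

The compounds shown leave open how far past the limit compound 1 and compound 3 lie. They also leave open how a fluoro, methoxy or nitrile group would read on this aromatic carbon.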